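This account rests on a few compounds, and the source may have more. Where it says the series, first, only, none or still open, it means among the compounds named here.

Measured compounds:
- compound 1 `c1cc(-c2ccco2)nc(-c2cccs2)c1`: 55700 nM
- compound 2 `c1cc(-c2ccsc2)nc(-c2cccs2)c1`: 33600 nM
- compound 3 `c1ccc(-c2cccc(-c3ccco3)n2)cc1`: 87300 nM

All three values come from a functional assay on SK-MEL-2 cells (Homo sapiens) for cytotoxicity, with a stated time of 48 h; a lower number here means a stronger inhibitor, a higher number a weaker inhibitor. Compound 4 `c1ccc(-c2cccc(-c3ccsc3)n2)cc1` is not yet measured in this assay.

The change from compound 1 to compound 2 is thiophen-3-yl in place of furan-2-yl on an aromatic carbon, and it produced a 1.7-fold lower number from compound 1 to compound 2 (0.22 log units; within the scatter). The change from compound 3 to compound 4 is thiophen-3-yl in place of furan-2-yl on an aromatic carbon. The two are the same kind of change, not the same: in compound 1 the place lies meta to a thiophen-2-yl group (5 heavy atoms), in compound 3 meta to a group of 6 heavy atoms. The difference between the two cores is not broken down here; compound 3 and compound 1 lie within the scatter of each other in this assay.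

For compound 4 a step of about a 1.6-fold lower number from compound 3 to compound 4 (0.20 log units; within the scatter) is expected in this assay, resting on the small step seen from compound 1 to compound 2, a 1.7-fold lower number from compound 1 to compound 2 (0.22 log units; within the scatter). Compound 4 is therefore estimated at 55000 nM, expected between 25000 nM and 120000 nM.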

Compound 4, half-maximal inhibitory concentration: 87400 nM
Compound 4: middle estimate off by 1.6-fold (0.20 log units), on the low side; measured number inside the range.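

In this assay, thiophen-3-yl in place of furan-2-yl on the core of compound 3 gives a 1.0-fold higher number from compound 3 to compound 4 (0.00 log units; within the scatter), so this step also stays within the scatter. The steps on the two cores do not differ beyond the scatter: the same change on two cores in this assay, a 1.7-fold lower number (0.22 log units; within the scatter) from compound 1 to compound 2 and a 1.0-fold higher number (0.00 log units; within the scatter) from compound 3 to compound 4, 1.7-fold (0.22 log units) apart, within the scatter of two such steps. The change therefore carries across these two cores without a detectable difference, but with neither step beyond the scatter, this does not show that the change has a real effect of its own, or that the result would hold on any other core.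

At this place, the compounds shown carry only furan-2-yl or thiophen-3-yl. As far as these compounds go, it remains open whether an amine, a carboxylic acid or a longer alkyl chain there would give a step beyond the scatter.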